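Swapping Methyl for Cyano in a Weakly Active Pair

This account rests on a few compounds, and the source may have more. Where it says the series, first, only, none or still open, it means among the compounds named here.

Compound 2 `Cc1ccc(-c2csc(N3C(=O)c4ccc(F)cc4C3=O)n2)cc1` was tested in a functional assay on PC-3 cells (Homo sapiens) for antiproliferative activity, read by MTT assay, with a stated time of 48 h (a lower number here means a stronger inhibitor, a higher number a weaker inhibitor), where compound 2 gives 44400 nM. Of the two numbers measured, this is the higher one, but its only companion, compound 1 `O=C1c2ccc(F)cc2C(=O)N1c1nc(-c2ccccc2)cs1`, sits within the scatter: in this assay compound 1 gives 40200 nM, and the step of a 1.1-fold higher number from compound 1 to compound 2 (0.04 log units; within the scatter) is too small to count as a real difference. Compound 3 `N#Cc1ccc(-c2csc(N3C(=O)c4ccc(F)cc4C3=O)n2)cc1` differs from compound 2 by cyano in place of methyl on an aromatic carbon. Among the compounds with values here, no measured step exchanges a methyl for a cyano, so the only guide is the earlier change at the same carbon, hydrogen to methyl, which gave a 1.1-fold higher number from compound 1 to compound 2 (0.04 log units; within the scatter). Within these two compounds, altering that carbon left the number essentially unchanged, so no step beyond the scatter is expected here either. The expected step is a 1.1-fold lower number from compound 2 to compound 3 (0.02 log units; within the scatter). Compound 3 is therefore estimated at 42000 nM, with a likely range from 15000 nM to 120000 nM.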

Compound 3, half-maximal inhibitory concentration: 43100 nM
Beside the measured number, compound 3's estimate is 1.0-fold (0.01 log units) below it, within the range that was stated.
By their numbers in this assay, from the lowest: compounds 1, 3 and 2 (each within the scatter of the next).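

Across hydrogen, methyl and cyano on this aromatic carbon, the number in this assay never moves beyond the scatter: cyano in place of methyl gives a 1.0-fold lower number from compound 2 to compound 3 (0.01 log units; within the scatter) and cyano in place of hydrogen gives a 1.1-fold higher number from compound 1 to compound 3 (0.03 log units; within the scatter) in the same reading. Cyano carries a nitrogen and a hydrogen-bond acceptor that methyl does not, yet in these three compounds that exchange leaves the number within the scatter, so this assay does not tell the three groups apart at this position. Nothing at hand offers an explanation for this flat result.

Still open, going by these compounds, is whether an amine, a carboxylic acid or a longer chain at this carbon would shift the number beyond the scatter. All three compounds share one core, so they cannot show whether a change elsewhere in the molecule would matter more.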